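The compounds below may be only part of what the source reports. "The series", "measured", "known", "first", "only" and "open" are said of these compounds alone.

The measured compounds are compound 1 `NCc1csc(NC(=O)c2ncccn2)n1`, compound 2 `Cc1csc(NC(=O)c2cc(C(C)(C)C)nn2Cc2ccccc2)n1` and compound 3 `CC(C)(C)c1cc(C(=O)Nc2ccncc2)n(Cc2ccccc2)n1`. In a physicochemical assay for solubility, read by nephelometry, measured as kinetic solubility, at pH 2.0 (on this read-out higher numbers stand for higher solubility and lower numbers for lower solubility), compound 1 gives > 100 ug/mL, a limit of the assay. Compound 2 gives < 1.6 ug/mL, likewise a limit. Compound 3 gives > 100 ug/mL, again a limit rather than a number.

Compound 3 thus stands at the limit of > 100 ug/mL in this assay, at which 2 of the 3 values shown sit, while compound 2 sits at the limit of < 1.6 ug/mL in this assay, at which 1 of the 3 values shown sits. Within the data shown here, the one measured step at this position is an at least 62-fold higher number from compound 2 to compound 3 (1.79 log units; beyond the scatter), a different swap from the one now considered.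

Compound 4 `CC(C)(C)c1cc(C(=O)Nc2ccccc2)n(Cc2ccccc2)n1` differs from compound 3 by phenyl in place of pyridin-4-yl on an amide-type nitrogen. Among the measured compounds shown here, no measured step covers this exchange, and since compound 3 is a limit, the size of any step from it is uncertain. Compound 4 is expected to give 25 ug/mL, within 4 ug/mL to 100 ug/mL. This estimate corresponds to an expected step of an at least 4.0-fold lower number from compound 3 to compound 4 (0.60 log units; beyond the scatter).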

Compound 4, solubility: 1.6 ug/mL
The estimate for compound 4 lay 16-fold (1.19 log units) above the measured number; the whole stated range lies above it.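

Exchanging pyridin-4-yl for phenyl on an amide-type nitrogen, with the shared core unchanged, gives an at least 62-fold lower number from compound 3 to compound 4 (1.79 log units; beyond the scatter) in this assay. Phenyl in place of 4-methyl-1,3-thiazol-2-yl on an amide-type nitrogen gives a number no lower from compound 2 to compound 4 (the limit leaves the size open) in this assay, so this step cannot be read. Nothing shown here explains the step from the pyridine ring to the phenyl ring.

Left open is how a pyridin-3-yl ring would read at this position. So is a phenyl ring carrying a dimethylamino group or a carboxylic acid.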